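Permeability of the diamine series: cyclohexyl to isopropyl

This account rests on a few compounds, and the source may have more. Where it says the series, first, only, none or still open, it means among the compounds named here.

Compound 2 `c1coc(CNCCCNc2ccnc3cc(CC4CCCCC4)ccc23)c1` is the reference. In an ADME assay for permeability, using PAMPA, with a stated time of 30 min, at pH 7.4 (a higher number here means that the compound crosses the layer faster, a lower number that the compound crosses the layer more slowly), compound 2 gives 23 10^-6 cm/s. Compound 1 `CC(C)Cc1ccc2c(NCCCNCc3ccco3)ccnc2c1` carries isopropyl in place of cyclohexyl on a saturated chain carbon bound to an aromatic carbon; in this assay compound 1 gives 23 10^-6 cm/s, and the step reads no change at the digits printed from compound 2 to compound 1 (within the scatter). Compound 3 `COc1ccc(F)cc1CNCCCNc1ccnc2cc(CC3CCCCC3)ccc12` differs from compound 2 in its core by 5-fluoro-2-methoxyphenyl in place of furan-2-yl on a saturated chain carbon bound to an amine nitrogen; in this assay compound 3 gives 23 10^-6 cm/s, and the step reads no change at the digits printed from compound 2 to compound 3 (within the scatter). Compound 4 `COc1ccc(F)cc1CNCCCNc1ccnc2cc(CC(C)C)ccc12` is not yet measured; it differs from compound 3 by isopropyl in place of cyclohexyl on a saturated chain carbon bound to an aromatic carbon. This is the same change, at the same place, as that from compound 2 to compound 1, and it occurs twice in the set. Because no change at the digits printed from compound 2 to compound 1 (within the scatter) was flat, the step to compound 4 is expected to be no change at the digits printed from compound 3 to compound 4 (within the scatter). Compound 4 is therefore estimated at 23 10^-6 cm/s in this assay, expected between 12 10^-6 cm/s and 42 10^-6 cm/s.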

Compound 4, apparent permeability: 23 10^-6 cm/s
Compound 4: the middle estimate sits on the measured number at the digits printed; the range from low to high includes it.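

In this assay the change from cyclohexyl to isopropyl reads no change at the digits printed from compound 3 to compound 4 (within the scatter) and carries from one core to the other: the same change on two cores in this assay, no change at the digits printed (within the scatter) from compound 2 to compound 1 and no change at the digits printed (within the scatter) from compound 3 to compound 4, 1.0-fold (0.00 log units) apart, within the scatter of two such steps

The change from furan-2-yl to 5-fluoro-2-methoxyphenyl reads no change at the digits printed from compound 1 to compound 4 (within the scatter) and carries in the same way: the same change on two cores in this assay, no change at the digits printed (within the scatter) from compound 2 to compound 3 and no change at the digits printed (within the scatter) from compound 1 to compound 4, 1.0-fold (0.00 log units) apart, within the scatter of two such steps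

This shows that both changes stay flat across these two cores only; it does not show that either would stay flat on a further core, and it gives no reason for the flat result.

Still open, on these data alone, is whether a carboxylic acid or an amine in place of isopropyl on a saturated chain carbon bound to an aromatic carbon would also leave the read-out level. The same holds for a longer chain at that place.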